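Pyrimidinyl for Dichlorophenyl on the Longer Linker

This account rests on a few compounds, and the source may have more. Where it says the series, first, only, none or still open, it means among the compounds named here.

The measured compounds, all tested in an assay on CHO cells for displacement of a labelled ligand from 5-hydroxytryptamine receptor 7 (Homo sapiens), read by scintillation counting, with a stated time of 60 min; a lower number here means a stronger inhibitor, a higher number a weaker inhibitor:
compound 1, `COc1ccc(/C=C2\NC(=O)N(CCCN3CCN(c4cccc(Cl)c4Cl)CC3)C2=O)cc1OC1CCCC1`, gives 380 nM.
compound 2, `COc1ccc(/C=C2\NC(=O)N(CCCN3CCN(c4ncccn4)CC3)C2=O)cc1OC1CCCC1`, gives > 1000 nM; this is a limit of the assay, not a number.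
compound 3, `COc1ccc(/C=C2\NC(=O)N(CCCCN3CCN(c4cccc(Cl)c4Cl)CC3)C2=O)cc1OC1CCCC1`, gives 125 nM.

Compound 3 shows the lowest of the two numbers; the difference between its core and that of compound 1 is not broken down here. Within the shared frame of compound 1, the change pyrimidin-2-yl in place of 2,3-dichlorophenyl on an amine nitrogen in a ring produced an at least 2.6-fold higher number from compound 1 to compound 2 (0.42 log units; beyond the scatter); how much further the loss goes is hidden because of the limit of > 1000 nM in this assay, at which 1 of the 3 values shown sits.

Compound 4, `COc1ccc(/C=C2\NC(=O)N(CCCCN3CCN(c4ncccn4)CC3)C2=O)cc1OC1CCCC1`, carries the same change on the core of compound 3: pyrimidin-2-yl in place of 2,3-dichlorophenyl on an amine nitrogen in a ring, at the very same place as before. Since compound 3 sits lower than compound 1 in this assay, the same shift should leave compound 4 a measurable number. Compound 4 is expected to reach 600 nM, within 250 nM to 2000 nM. That is, a step of a 4.8-fold higher number from compound 3 to compound 4 (0.68 log units; beyond the scatter) is expected, resting on the earlier step, an at least 2.6-fold higher number from compound 1 to compound 2 (0.42 log units; beyond the scatter), which was only a lower bound of the loss.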

Compound 4, inhibition constant: 298 nM
Compound 4: middle estimate off by 2.0-fold (0.30 log units), on the high side, within the range that was stated.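

In this assay, pyrimidin-2-yl in place of 2,3-dichlorophenyl on an amine nitrogen in a ring gives a 2.4-fold higher number from compound 3 to compound 4 (0.38 log units; beyond the scatter), so the core of compound 3 shows the same direction of change as the core of compound 1. Set side by side, the two steps read: the same change on two cores in this assay, an at least 2.6-fold higher number (0.42 log units; beyond the scatter) from compound 1 to compound 2 and a 2.4-fold higher number (0.38 log units; beyond the scatter) from compound 3 to compound 4; the limit leaves it open whether they differ Compound 2 gives > 1000 nM, which is a limit of the assay and not a number, so the series shows that the direction carries from one core to the other but not that the size of the step does.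

The compounds shown leave open whether this direction would hold for other groups on the same amine nitrogen, such as a plain phenyl or a pyridin-2-yl. They also leave open how the pyrimidin-2-yl and 2,3-dichlorophenyl pair would compare on a longer chain than that of compound 3.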